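A Second Fluoro on the Aryl Ring, Carried Across Two Cores

The source may hold more compounds than are shown below. What is called first, only, known or untested is meant among the compounds shown, and "the series" means these compounds.

Three compounds sharing a chloropyrimidine-hydrazone framework were examined in an ADME assay on HT-29 cells (Homo sapiens) for inhibition, read by MTT assay, with a stated time of 72 h; a lower number here means a stronger inhibitor, a higher number a weaker inhibitor. Compound 1 `C=CC(=O)Nc1cccc(Nc2nc(N/N=C(\C)c3ccc(F)cc3)ncc2Cl)c1` gives 5050 nM in this assay. Compound 2 `C=CC(=O)Nc1cccc(Nc2nc(N/N=C(\C)c3ccc(F)cc3F)ncc2Cl)c1` differs from compound 1 only by fluoro in place of hydrogen on an aromatic carbon, and this produced a step of a 1.2-fold lower number from compound 1 to compound 2 (0.06 log units; within the scatter). In this assay compound 2 gives 4360 nM. Compound 3 `CN(C)C/C=C/C(=O)Nc1cccc(Nc2nc(N/N=C/c3ccc(F)cc3)ncc2Cl)c1` carries a different acrylamide and hydrazone portion; the difference between the core of compound 1 and the core of compound 3 is not broken down here. In this assay compound 3 gives 3300 nM, and the values of compound 2 and compound 3 lie within the usual scatter of one another, so no order among them is asserted.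

Compound 4 `CN(C)C/C=C/C(=O)Nc1cccc(Nc2nc(N/N=C/c3ccc(F)cc3F)ncc2Cl)c1` has not yet been measured. It differs from compound 3 by fluoro in place of hydrogen on an aromatic carbon, the same change as that from compound 1 to compound 2, and at the same place: an aromatic carbon ortho to a large group and meta to a fluoro group, taking 4-fluorophenyl to 2,4-difluorophenyl. Because the earlier instance gave only a 1.2-fold lower number from compound 1 to compound 2 (0.06 log units; within the scatter), compound 4 is expected to sit close to compound 3, with a step of a 1.2-fold lower number from compound 3 to compound 4 (0.07 log units; within the scatter). The estimate for compound 4 in this assay is 2800 nM, with a likely range from 1400 nM to 5600 nM.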

Compound 4, half-maximal inhibitory concentration: 2920 nM
Estimate against measurement, compound 4: 1.0-fold (0.02 log units) below; the measured number falls inside the stated range.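

In this assay, fluoro in place of hydrogen on the core of compound 3 gave a 1.1-fold lower number from compound 3 to compound 4 (0.05 log units; within the scatter), so 4-fluorophenyl to 2,4-difluorophenyl again produced a step within the scatter, as it had on the core of compound 1. The two instances agree with each other: the same change on two cores in this assay, a 1.2-fold lower number (0.06 log units; within the scatter) from compound 1 to compound 2 and a 1.1-fold lower number (0.05 log units; within the scatter) from compound 3 to compound 4, 1.0-fold (0.01 log units) apart, within the scatter of two such steps. This shows that the change carried from one core to the other without a readable step on either, but it does not show that the second fluoro has any effect of its own in this assay, and two cores alone do not establish that the same would hold on any other core in the series.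

The compounds shown leave open what a different group would do on the same aromatic carbon, such as a chloro, a methyl, a methoxy or a nitrile in place of the fluoro, and whether any of these would give a step beyond the scatter. They also leave open whether the result would stay the same with a diethylamino group or a longer amine chain in place of the dimethylamino group of compound 4.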